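Extending the Aryl Ether Chain with a Benzyl Group

The source may report more compounds than this note shows. Statements on the series, on what has been measured and on what is new or still open speak of the compounds shown alone.

Compound 1, `CCCC(=O)NCCCc1cc(OC)ccc1OCc1ccccc1`, gives 0.00103 nM in an assay on CHO cells for displacement of a labelled ligand from melatonin receptor type 1B (Homo sapiens), read by scintillation counting, with a stated time of 60 min; a higher number here means a weaker inhibitor, a lower number a stronger inhibitor.
Compound 2, `CCOc1ccc(OC)cc1CCCNC(C)=O`, gives 1.59 nM in this assay.
Compound 3, `CCCOc1ccc(OC)cc1CCCNC(C)=O`, gives 2.12 nM in this assay.

Compound 2 stands second highest of the three numbers. Its nearest neighbour is compound 3, reached by a 1.3-fold higher number from compound 2 to compound 3 (0.12 log units; within the scatter), a step within the scatter. Within the data shown here, compound 1 lies far away with a much lower number, but it also carries a different acyl group, so no single step links it to compound 2. Compound 4, `COc1ccc(OCCCc2ccccc2)c(CCCNC(C)=O)c1`, differs from compound 2 by benzyl in place of hydrogen on a saturated chain carbon, two bonds along the chain from an oxygen on an aromatic ring. Among the measured compounds shown here, only the step from compound 2 to compound 3 touches the same chain carbon, and it stayed within the scatter. Compound 1, which also holds a benzyl group in its ether side chain, shows that such a chain is compatible with a very low number, though its second difference leaves the weight of the benzyl alone unclear. A lower number is therefore expected for compound 4, by a 3.2-fold lower number from compound 2 to compound 4 (0.50 log units; beyond the scatter), with wide uncertainty. Compound 4 is estimated at 0.5 nM, in the range 0.05 nM to 5 nM.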

Compound 4, inhibition constant: 72.2 nM
Compound 4: middle estimate off by 140-fold (2.16 log units), on the low side; the whole stated range lies below it.
By their numbers in this assay, from the lowest: compound 1; then compounds 2 and 3 (each within the scatter of the next); then compound 4.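

In this assay, the saturated chain carbon where methyl produced no change beyond the scatter responds strongly to a larger group: benzyl in place of hydrogen there gives a 45-fold higher number from compound 2 to compound 4 (1.66 log units; beyond the scatter). Phenyl in place of hydrogen on a saturated chain carbon, three bonds along the chain from an oxygen on an aromatic ring, gives a 34-fold higher number from compound 3 to compound 4 (1.53 log units; beyond the scatter), so the flat response seen with methyl does not extend to this aromatic-bearing chain. No measured evidence is available to explain this change.

The compounds shown leave open whether the higher number follows from the phenyl ring itself or from the length of the chain, a question that a plain butyl or pentyl chain, or cyclohexyl in place of phenyl, would address. They also leave open whether the same step would hold with the butanoyl amide of compound 1 in place of the acetamide.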